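The source may hold more compounds than are shown below. What is called first, only, known or untested is meant among the compounds shown, and "the series" means these compounds.

Compound 1 `Nc1ccc(-c2cc(=O)c3c(N)c(F)c(CO)c(F)c3o2)cc1F` gives 24000 nM in a functional assay on HeLa cells (Homo sapiens) for cytotoxicity, read by neutral red uptake, with a stated time of 3 days; a higher number here means a weaker inhibitor, a lower number a stronger inhibitor.
Compound 2 `CN(C)CCC(=O)OCc1c(F)c(N)c2c(=O)cc(-c3ccc(N)c(F)c3)oc2c1F` gives 11000 nM in this assay.
Compound 3 `COCc1c(F)c(N)c2c(=O)cc(-c3ccc(N)c(F)c3)oc2c1F` gives only a limit, > 100000 nM, in this assay.

The three measured compounds share one core and differ only in the group on the oxygen of the saturated carbon. Compound 3 stands at the limit of > 100000 nM in this assay, at which 1 of the 3 values shown sits, so its number is a limit and not a value. The steps of an at least 4.1-fold higher number from compound 1 to compound 3 (0.61 log units; beyond the scatter) and an at least 9.0-fold higher number from compound 2 to compound 3 (0.95 log units; beyond the scatter) both run up to that limit, while a 2.2-fold lower number from compound 1 to compound 2 (0.34 log units; beyond the scatter) is modest. Compound 4 `NCc1c(F)c(N)c2c(=O)cc(-c3ccc(N)c(F)c3)oc2c1F` differs from compound 3 by amino in place of methoxy on a saturated chain carbon bound to an aromatic carbon. Within the data shown here, no measured step swaps methoxy for amino; the nearest is the reverse of the step from compound 1 to compound 3, in which the methyl on the oxygen is the only change. Amino, like the hydroxyl of compound 1, brings back a hydrogen-bond donor, so the number for compound 4 is expected to fall back toward that of compound 1. Compound 4 is estimated at 30000 nM, with a range from 8000 nM to 100000 nM. The step of an at least 3.3-fold lower number from compound 3 to compound 4 (0.52 log units; beyond the scatter) is therefore expected, with a real chance that the assay again reports only a limit.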

Compound 4, half-maximal inhibitory concentration: 8800 nM
The estimate for compound 4 lay 3.4-fold (0.53 log units) above the measured number; the measured number falls inside the stated range.
By their numbers in this assay, from the lowest: compounds 4 and 2 (each within the scatter of the next); then compound 1. At a limit, above all of these: compound 3.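

On the saturated chain carbon bound to an aromatic carbon, amino in place of methoxy gives an at least 11-fold lower number from compound 3 to compound 4 (1.05 log units; beyond the scatter) in this assay. The number for compound 3 is only a limit, so the size of that step is a bound and not a value: the limit of > 100000 nM in this assay, at which 1 of the 4 values shown sits. Amino in place of hydroxy gives a 2.7-fold lower number from compound 1 to compound 4 (0.44 log units; beyond the scatter), and amino in place of ((2-(dimethylamino)ethyl)carbonyl)oxy gives a 1.3-fold lower number from compound 2 to compound 4 (0.10 log units; within the scatter), so of the four groups shown at this place, only methoxy leaves the number at a limit.

On these data alone, whether dimethylamino, a longer chain ending in amino, or a carboxylic acid at this place would match amino remains open. As far as these compounds go, what sets methoxy apart from the other three groups also remains open.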